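The compounds below may be only part of what the source reports. "The series", "measured", "known", "first", "only" and "open" are said of these compounds alone.

The shared core is that of compound 1, `NS(=O)(=O)c1ccc(N/C(S)=N\c2ccnc3cc(C(F)(F)F)ccc23)cc1`, which in a functional assay on HeLa cells (Homo sapiens) for antiproliferative activity, read by sulforhodamine B assay, with a stated time of 48 h (a higher number here means a weaker inhibitor, a lower number a stronger inhibitor), gives 36600 nM. Compound 2, `Cc1noc(NS(=O)(=O)c2ccc(N/C(S)=N\c3ccnc4cc(C(F)(F)F)ccc34)cc2)c1C`, carries the same core; in this assay compound 2 was reported only as "not active" (no number reported), with no number attached, so on the figures shown its standing is undefined, and the sole numbered point of reference is compound 1. Compound 3, `O=S(=O)(Nc1nccs1)c1ccc(N/C(S)=N\c2ccnc3cc(C(F)(F)F)ccc23)cc1`, differs from compound 2 in one place: 1,3-thiazol-2-yl in place of 3,4-dimethyl-1,2-oxazol-5-yl on a sulfonamide nitrogen. Going by the values given here, no step between measured compounds exists for this change, so its size and direction in this assay cannot be taken from the data; with compound 2 inactive and compound 1 at 36600 nM, compound 3 is expected to stay weak, with no movement beyond the scatter that can be foreseen. For compound 3 the estimate in this assay is 60000 nM, in a range from 15000 nM to 250000 nM, with a real chance that only a limit is reported.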

Compound 3, half-maximal inhibitory concentration: 95200 nM
The estimate for compound 3 lay 1.6-fold (0.20 log units) below the measured number; the measured number falls inside the stated range.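

In this assay, 1,3-thiazol-2-yl in place of hydrogen on a sulfonamide nitrogen gives a 2.6-fold higher number from compound 1 to compound 3 (0.42 log units; beyond the scatter), so a ring at this position weakens the antiproliferative read-out modestly, though still with a numbered result. Compound 2 was reported only as not active and has no number, so the step from it to compound 3, the exchange of 3,4-dimethyl-1,2-oxazol-5-yl for 1,3-thiazol-2-yl, cannot be read. Nothing shown explains the rise in the number from the unsubstituted sulfonamide.

With only one numbered substituent at this position, no trend can be drawn across ring types. On these data alone, how a small acetyl group, a methyl group or a phenyl ring on the same sulfonamide nitrogen would compare with hydrogen and with 1,3-thiazol-2-yl remains open.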